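Triazole to thiazole on the amine nitrogen of compound 2

The source may hold more compounds than are shown below. What is called first, only, known or untested is meant among the compounds shown, and "the series" means these compounds.

Measured compounds:
compound 1 `CCC(CC)(c1nnc[nH]1)c1ccc(-c2ccc3cc(F)cc(F)c3c2)[nH]c1=O` gives 89 nM
compound 2 `CC(C)C(Nc1nnc[nH]1)c1ccc(-c2ccc3cccc(F)c3c2)[nH]c1=O` gives 22 nM

In an assay on CHO cells for displacement of a labelled ligand from prostaglandin E2 receptor EP3 subtype (Homo sapiens), read by radioligand binding (on this read-out higher numbers stand for weaker inhibition and lower numbers for stronger inhibition), compound 2 gives 22 nM, the lower of the two numbers recorded; compound 1 gives 89 nM, a gap that lies beyond the usual scatter. Going by the values given here, compound 1 and compound 2 differ at more than one place, so no single step between them can be read off, and no measured pair isolates the change examined here.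

Compound 3 `CC(C)C(Nc1nccs1)c1ccc(-c2ccc3cccc(F)c3c2)[nH]c1=O` is compound 2 with one alteration: 1,3-thiazol-2-yl in place of 4H-1,2,4-triazol-3-yl on an amine nitrogen. The entering group keeps the count of two hydrogen-bond acceptors but carries no hydrogen-bond donor, where the leaving group has one. Among the compounds with values here, no measured pair in this set shows the effect of such an exchange, so the direction and size of the step rest on judgement alone. The expectation is a modest weakening, of a size near the edge of the scatter, with a wide range either way.

The estimated step in this assay from compound 2 to compound 3 is a 2.3-fold higher number from compound 2 to compound 3 (0.36 log units; beyond the scatter). Compound 3 is expected to give about 50 nM, within a range of 15 nM to 200 nM.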

Compound 3, inhibition constant: 9.4 nM
Estimate against measurement, compound 3: 5.3-fold (0.73 log units) above; measured number below the stated range.
By their numbers in this assay, from the lowest: compound 3; then compound 2; then compound 1.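

In this assay, going by these compounds alone, 1,3-thiazol-2-yl in place of 4H-1,2,4-triazol-3-yl on the amine nitrogen gives a 2.3-fold lower number from compound 2 to compound 3 (0.37 log units; beyond the scatter), the only step in this set that isolates a single place, and it shows that the number at this position responds to the identity of the five-membered aromatic ring. The entering group carries no hydrogen-bond donor where the leaving group has one, yet the number falls, so in this pair the donor of the leaving group is not needed to keep the number at the level of compound 2. No measured data on hand account for the size or direction of this step.

This one pair cannot separate the loss of the donor from the other differences between the two rings, and a 1,3-oxazol-2-yl or pyridin-2-yl group on the same amine nitrogen would help to tell these apart. As far as these compounds go, compound 1 differs from compound 2 and compound 3 at more than one place, so its steps to them cannot be read, and whether the exchange would have the same effect on other substitution of the shared core remains open.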